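Replacing the Amide Aryl Group in a Dopamine Transporter Series

The source may hold more compounds than are shown below. What is called first, only, known or untested is meant among the compounds shown, and "the series" means these compounds.

Compound 1 `OC(Cc1ccccc1)CN1CCC(NCCSC(c2ccc(F)cc2)c2ccc(F)cc2)CC1` gives 31.4 nM in an assay on membranes from striatum (strain Sprague-Dawley) for displacement of a labelled ligand from sodium-dependent dopamine transporter (Rattus norvegicus), read by scintillation counting, with a stated time of 120 min; on this read-out lower numbers stand for stronger inhibition and higher numbers for weaker inhibition. Compound 2 `O=C(c1ccc(F)cc1)N1CCC(NCCSC(c2ccc(F)cc2)c2ccc(F)cc2)CC1` gives 7.04 nM in this assay.

Compound 2 has the lowest of the two numbers; its nearest neighbour is compound 1, separated by a 4.5-fold lower number from compound 1 to compound 2 (0.65 log units; beyond the scatter). Compound 3 `O=C(c1cc2ccccc2[nH]1)N1CCC(NCCSC(c2ccc(F)cc2)c2ccc(F)cc2)CC1` differs from compound 2 by 1H-indol-2-yl in place of 4-fluorophenyl on a carbonyl carbon. Among the measured compounds shown here, the only measured step, a 4.5-fold lower number from compound 1 to compound 2 (0.65 log units; beyond the scatter), swaps the whole substituent on the ring nitrogen, so it does not isolate an exchange of the aryl group on the carbonyl. For the measured compounds named here, with no direct precedent, the estimated step of a 1.1-fold higher number from compound 2 to compound 3 (0.06 log units; within the scatter) is none beyond the scatter. Compound 3 is therefore expected near 8 nM, within 2 nM to 35 nM.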

Compound 3, inhibition constant: 177 nM
Beside the measured number, compound 3's estimate is 22-fold (1.34 log units) below it; measured number above the stated range.
By their numbers in this assay, from the lowest: compound 2; then compound 1; then compound 3.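

At this position on the carbonyl carbon, the aryl group matters: 1H-indol-2-yl in place of 4-fluorophenyl gives a 25-fold higher number from compound 2 to compound 3 (1.40 log units; beyond the scatter) in this assay and shows that the position does not treat these two aromatic groups alike. Against the 2-hydroxy-3-phenylpropyl substituent, (1H-indol-2-yl)carbonyl on the ring nitrogen gives a 5.6-fold higher number from compound 1 to compound 3 (0.75 log units; beyond the scatter) and so reverses the gain seen with (4-fluorophenyl)carbonyl. As far as these compounds go, whether a plain phenyl or a 1-methyl-1H-indol-2-yl group on the carbonyl would stay nearer compound 2 or compound 3 remains open. No measurement available here accounts for this loss.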